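A carbonyl group gives way in compound 3

A few compounds are considered here, and "the series" means these few. Any claim that something is new, unique, unknown or untested is made for them only; others in the source may bear on it.

Measured so far in a functional assay on HCT-116 cells (Homo sapiens) for inhibition; on this read-out higher numbers stand for an effect only at larger amounts of compound and lower numbers for an effect already at smaller amounts:
- compound 1 `COc1cc(N2CCN(C(=O)C3CCC(O)CC3)CC2)ccc1Nc1nc(NC2CCCCC2)c2nc[nH]c2n1`: 14 nM
- compound 2 `COc1cc(N2CCN(Cc3ccccn3)CC2)ccc1Nc1nc(NC2CCCCC2)c2nc[nH]c2n1`: 89 nM
- compound 3 `COc1cc(N2CCC(C(=O)N3CCC(N(C)C)C3)CC2)ccc1Nc1nc(NC2CCCCC2)c2nc[nH]c2n1`: 77 nM

Compound 3 sits with compound 2 at the upper end of these three numbers, the two lying within the scatter of each other, while compound 1 shows a clearly lower number. Compound 4 `CCN(CC)CC1CCN(c2ccc(Nc3nc(NC4CCCCC4)c4nc[nH]c4n3)c(OC)c2)CC1` keeps the shared core and changes one side group: (diethylamino)methyl comes in place of (3-(dimethylamino)pyrrolidin-1-yl)carbonyl on a saturated ring carbon ((diethylamino)methyl in place of (3-(dimethylamino)pyrrolidin-1-yl)carbonyl on a saturated ring carbon).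

For the measured compounds named here, only one measured step bears on this, and only loosely: a 6.4-fold higher number from compound 1 to compound 2 (0.80 log units; beyond the scatter), with (pyridin-2-yl)methyl in place of (4-hydroxycyclohexyl)carbonyl on an amine nitrogen in a ring. That step too exchanges a carbonyl group for a methyl group of this kind, but on a nitrogen rather than on a saturated ring carbon. Compound 3 already shares the level of compound 2 at 89 nM, so no more than a small step towards a higher number is expected in this assay. The step expected is a 1.3-fold higher number from compound 3 to compound 4 (0.11 log units; within the scatter), which stays small. For compound 4 the estimate is 100 nM, with an expected range of 35 nM to 280 nM.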

Compound 4, half-maximal effective concentration: 55 nM
Compound 4: middle estimate off by 1.8-fold (0.26 log units), on the high side, and the stated range covers the measured number.
By their numbers in this assay, from the lowest: compound 1; then compounds 4, 3 and 2 (each within the scatter of the next).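

In this assay the exchange on this saturated ring carbon gives a 1.4-fold lower number from compound 3 to compound 4 (0.15 log units; within the scatter) and leaves the two compounds within the scatter of each other, although the entering (diethylamino)methyl has fewer heavy atoms than (3-(dimethylamino)pyrrolidin-1-yl)carbonyl and lacks both its carbonyl and its five-membered ring. At this place, then, neither the carbonyl nor that ring is needed for a number of this size, and the earlier exchange on an amine nitrogen in a ring, which gave a 6.4-fold higher number from compound 1 to compound 2 (0.80 log units; beyond the scatter), does not carry over to this carbon. Nothing available explains why the two groups give such close numbers.

Both groups still carry an amine nitrogen, so the compounds shown leave open what a group without one, such as a plain ethyl or a hydroxymethyl, or one with a carboxylic acid, would give on this carbon. They also leave open how a (diethylamino)carbonyl group would read in this assay, a group that would separate the loss of the carbonyl from the loss of the ring.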